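The source may report more compounds than this note shows. Statements on the series, on what has been measured and on what is new or still open speak of the compounds shown alone.

Measured compounds:
Compound 1, `Cc1ccc(NS(=O)(=O)C2CCCCC2=O)c(C)c1` — 15.6% in a functional assay on BGC-823 cells (Homo sapiens) for antiproliferative activity, read by sulforhodamine B assay, tested at 100 ug/mL; a higher number here means more inhibition at the concentration tested (going by the name of the read-out), a lower number less inhibition
Compound 2, `O=C1CCCCC1S(=O)(=O)Nc1ccc(Cl)cc1` — 16%
Compound 3, `O=C1CCCCC1S(=O)(=O)Nc1ccc(Cl)c(Cl)c1` — 5.54%

Compound 2 is the reference point for the step considered here. In this assay compound 2 gives 16%, and compound 1 gives 15.6%, a number that lies within the scatter of that of compound 2, so the two cannot be told apart. Compound 3 sits further off: the step of a number 10.5 percentage points lower from compound 2 to compound 3 (beyond the scatter) is the only one beyond the scatter among the three, and it comes with chloro in place of hydrogen on an aromatic carbon.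

The unmeasured compound 4, `Cc1ccc(NS(=O)(=O)C2CCCCC2=O)cc1`, differs from compound 2 in one place: methyl in place of chloro on an aromatic carbon. Among the compounds with values here, no measured step swaps a methyl for a chloro directly. The step from compound 2 to compound 3 tells only what a second chloro did, and compound 1, which carries two methyl groups, is not a single-change partner of compound 2; its value and that of compound 2 merely show that a methyl-bearing ring and a chloro-bearing ring can give numbers within the scatter of each other. On that basis compound 4 is expected to move little: the expected step of a number 1 percentage points lower from compound 2 to compound 4 (within the scatter) is not beyond the scatter. Compound 4 is therefore estimated at 15%, with a range from 5% to 25%.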

Compound 4, a percentage reported as inhibition, at one concentration (the size of the read-out at that concentration, not a potency): 32.1%
Compound 4: middle estimate off by 17.1 percentage points, on the low side; measured number above the stated range.
By their numbers in this assay, from the lowest: compound 3; then compounds 1 and 2 (each within the scatter of the next); then compound 4.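

In this assay, within the data shown here, the single atom attached to the ring para to a large group proves to matter, a point the earlier compounds could not settle: with methyl in place of chloro on an aromatic carbon, the change gives a number 16.1 percentage points higher from compound 2 to compound 4 (beyond the scatter) and is not a small exchange at this position. Among these compounds, the only earlier step at the ring added a second chloro and lowered the number, whereas this one shows that a change at the chloro position itself can raise it. The other step, with hydrogen in place of methyl on an aromatic carbon, gives a number 16.5 percentage points higher from compound 1 to compound 4 (beyond the scatter) and shows that a methyl-bearing ring does not fix the number on its own, since the methyl pattern on the ring also counts. Nothing available here bears on why either change moves the number.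

On these data alone, what an ethyl group, a methoxy group or an amine would give at this same position remains open, as does the result for a ring with only hydrogen there. As far as these compounds go, these numbers also describe inhibition at a single concentration in one cell line, so whether the methyl compound keeps its lead at other concentrations or in other cells stays unknown.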